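The source may report more compounds than this note shows. Statements on the series, on what has been measured and on what is new or still open speak of the compounds shown alone.

Measured compounds in a functional assay on K562 cells (Homo sapiens) for cytotoxicity, read by MTT assay, with a stated time of 48 h; a lower number here means a stronger inhibitor, a higher number a weaker inhibitor:

Compound 1, `CC(C)=CCc1cc(C(=O)/C=C/c2ccc(O)cc2)c(O)cc1O`, gives > 10000 nM; this is a limit of the assay, not a number.
Compound 2, `CC(C)=CCc1cc(-c2coc3cc(O)cc(O)c3c2=O)ccc1O`, gives > 10000 nM; again a limit of the assay.
Compound 3, `C=C[C@@](C)(/C=C/c1ccc(O)cc1)CC[C@@H](O)C(C)(C)O`, gives > 10000 nM; also a limit of the assay.

Where compound 3 stands: only a limit is known for it in this assay, and the same holds for the two other compounds, since (the limit of > 10000 nM in this assay, at which 3 of the 3 values shown sit). Within the data shown here, no measured pair differs in a single place, so no measured step is available to size the scatter against.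

The next compound, compound 4, `C=C[C@@](C)(/C=C/c1ccc(O)cc1)C/C=C/C(C)(C)O`, has not yet been measured in this assay. It differs from compound 3 as follows: 3-hydroxy-3-methylbut-1-en-1-yl in place of 2,3-dihydroxy-3-methylbutyl on a saturated chain carbon, two bonds along the chain from two double-bonded chain carbons.

With all three measured values sitting at the limit, no direction of change can be read from the data. The expectation is that compound 4 will also lie at or near that limit, so the step that the limit leaves unreadable from compound 3 to compound 4 is expected to be none beyond the scatter. Compound 4 is estimated at 20000 nM, with a range from 5000 nM to 80000 nM, and it is likely that the assay will again report only a limit.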

Compound 4, half-maximal inhibitory concentration: > 10000 nM
Compound 4 gave a limit, no number; the forecaster's own chance of this, stated with the estimate: 75%; the middle value is on the limit's open side.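

Compound 3 and compound 4 both give only a limit in this assay, not a number, so no step can be read between them: the limit of > 10000 nM in this assay, at which 4 of the 4 values shown sit.

The compounds shown leave open whether any of them has a measurable half-maximal inhibitory concentration in this assay, and what 3-hydroxy-3-methylbut-1-en-1-yl in place of 2,3-dihydroxy-3-methylbutyl changes in that read-out.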